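The source may report more compounds than this note shows. Statements on the series, on what has been measured and on what is new or still open speak of the compounds shown alone.

Measured in a functional assay on DU-145 cells (Homo sapiens) for antiproliferative activity, read by sulforhodamine B assay, with a stated time of 3 days; on this read-out lower numbers stand for stronger inhibition of growth and higher numbers for weaker inhibition of growth:

- compound 1 `COc1ccc(NC(=O)c2cccc(Nc3ncc(F)c(Nc4ccc(F)cc4)n3)c2)cc1` gives > 10000 nM (a limit)
- compound 2 `CN1CCC(C(=O)Nc2cccc(Nc3ncc(F)c(Nc4ccc(F)cc4)n3)c2)CC1` gives 1150 nM
- compound 3 `O=C(Nc1cccc(Nc2ncc(F)c(Nc3ccc(F)cc3)n2)c1)c1ccccc1` gives > 10000 nM (a limit)

Compound 1 stands at the limit of > 10000 nM in this assay, at which 2 of the 3 values shown sit, so its place is known only as a limit and not as a number. Compound 4 `Cn1ccnc1NC(=O)c1cccc(Nc2ncc(F)c(Nc3ccc(F)cc3)n2)c1` has yet to be measured. It keeps the core of compound 1 and changes one group, with 1-methyl-1H-imidazol-2-yl in place of 4-methoxyphenyl on an amide-type nitrogen.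

Going by the values given here, no measured step makes this exact change, so the evidence is indirect. Compound 3 shows an at least 8.6-fold higher number from compound 2 to compound 3 (0.93 log units; beyond the scatter), the change being phenyl in place of 1-methylpiperidin-4-yl on a carbonyl carbon. The remaining step, a step that the two limits leave unreadable from compound 1 to compound 3, gives no usable size. Of these three compounds, only compound 2 yields a number, and it alone lacks a terminal ring of carbon only. Compound 4 also lacks such a ring, but its ring is aromatic and its carbamoyl link is that of compound 1, so the parallel is loose.

Going by compound 2 and an at least 8.6-fold lower number from compound 1 to compound 2 (0.93 log units; beyond the scatter), a modest fall in the number is expected in this assay, although compound 4 may yet remain at the limit. The estimated change is an at least 2.5-fold lower number from compound 1 to compound 4 (0.39 log units; beyond the scatter). For compound 4 the expected value is 4000 nM, with an estimated range of 1200 nM to 10000 nM.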

Compound 4, concentration for 50% growth inhibition: 15100 nM
Compound 4: middle estimate off by 3.8-fold (0.58 log units), on the low side; the measured number lies above the stated range.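

In this assay compound 4 gives 15100 nM, so with 1-methyl-1H-imidazol-2-yl on the amide-type nitrogen, this position now carries a measured number on the carbamoyl link, which compound 1 does not provide. Compound 1 and compound 3 each stand at a limit and not at a number, so the steps from them to compound 4 cannot be read: the limit of > 10000 nM in this assay, at which 2 of the 4 values shown sit. Going by these compounds alone, the one readable step is a 13-fold higher number from compound 2 to compound 4 (1.12 log units; beyond the scatter), and it shows that lacking a terminal ring of carbon only does not by itself bring a compound to the level of compound 2, as compound 4 also lacks such a ring.

The compounds shown do not separate the part played by the 1-methylpiperidin-4-yl ring from that of the link, as compound 2 and compound 4 differ in both, and a 1-methylpiperidin-4-yl group on the amide-type nitrogen of the carbamoyl link would address this directly. Also open, going by these compounds, is how an open-chain amine such as a 2-(dimethylamino)ethyl group on that nitrogen would read, and whether any carbamoyl compound can reach the number of compound 2.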